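This account rests on a few compounds, and the source may have more. Where it says the series, first, only, none or still open, it means among the compounds named here.

Among the measured compounds shown here, compound 2, `O=S(=O)(O)CCCSC(=S)NCc1cccnc1`, has the higher of the two numbers so far in a functional assay on MDA-MB-468 cells (Homo sapiens) for cytotoxicity, read by resazurin assay, with a stated time of 72 h (on this read-out higher numbers stand for weaker inhibition and lower numbers for stronger inhibition), where compound 2 gives 11100 nM. For the measured compounds named here, its nearest neighbour is compound 1, `CC(=O)CCSC(=S)NCc1cccnc1`, which in this assay gives 4220 nM; the step of a 2.6-fold higher number from compound 1 to compound 2 (0.42 log units; beyond the scatter) is the only measured step and it is modest.

Compound 3, `S=C(NCc1cccnc1)SCCc1nnn[nH]1`, differs from compound 2 by 1H-tetrazol-5-yl in place of sulfomethyl on a saturated chain carbon, two bonds along the chain from a sulfur. Going by the values given here, no measured step covers this exchange: the one step on record swaps acetyl for sulfomethyl at the same place on the chain, and it moved the number by a modest amount, so a step of similar size in either direction, or none beyond the scatter, seems possible here. With the sulfomethyl group gone, the number is expected to move back towards that of compound 1, giving an expected step of a 1.6-fold lower number from compound 2 to compound 3 (0.20 log units; within the scatter) in this assay. Compound 3 is therefore estimated at 7000 nM, within a range of 2500 nM to 20000 nM.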

Compound 3, half-maximal inhibitory concentration: > 100000 nM
Compound 3 was reported as a limit (the forecaster's own chance of this, stated with the estimate: 10%); at least 14-fold (1.15 log units) between middle value and limit.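

In this assay, compound 3 is reported only as a limit and not as a number: the limit of > 100000 nM in this assay, at which 1 of the 3 values shown sits. Even so, the result shows that this place on the chain is far more sensitive to the group it carries than the earlier modest step suggested: 1H-tetrazol-5-yl in place of sulfomethyl gives an at least 9.0-fold higher number from compound 2 to compound 3 (0.95 log units; beyond the scatter), and 1H-tetrazol-5-yl in place of acetyl gives an at least 23-fold higher number from compound 1 to compound 3 (1.37 log units; beyond the scatter). Of the three groups, only 1H-tetrazol-5-yl brings a ring, and it gives the weakest result, though three compounds cannot show that the ring itself is responsible.

From the compounds shown here alone, whether a carboxylic acid or an amine at this place would stay close to compound 1, or a phenyl ring would match 1H-tetrazol-5-yl, remains open. Going by these compounds, the full size of both new steps also remains unknown.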